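The compounds below may be only part of what the source reports. "The series", "measured", "known", "first", "only" and "open" are said of these compounds alone.

In an assay on isolated protein (strain Sprague-Dawley) for inhibition of Amine oxidase [flavin-containing] A (Rattus norvegicus), read by spectrophotometry, with a stated time of 5 min, tested at 10 uM (on this read-out higher numbers stand for more inhibition at the one concentration tested (going by the name of the read-out) and lower numbers for less inhibition), compound 1 `O=c1cc(CCl)c2ccc(OCc3cccc(Cl)c3)cc2o1` gives 21%, and compound 2 `O=Cc1cc(=O)oc2cc(OCc3cccc(Cl)c3)ccc12` gives 14%; the step of a number 7 percentage points lower from compound 1 to compound 2 (within the scatter) is the only one measured, and it stays within the scatter. Compound 3 `N#Cc1cc(=O)oc2cc(OCc3cccc(Cl)c3)ccc12` differs from compound 2 by cyano in place of formyl on an aromatic carbon. Within the data shown here, no measured step swaps these two groups, and the one known change at that position, a number 7 percentage points lower from compound 1 to compound 2 (within the scatter), moved little, so for compound 3 the step of no change at the digits printed from compound 2 to compound 3 (within the scatter) is expected to stay within the scatter. Compound 3 is therefore estimated to give 14%, somewhere between 0% and 30%.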

Compound 3, a percentage reported as inhibition, at one concentration (the size of the read-out at that concentration, not a potency): 23%
The estimate for compound 3 lay 9 percentage points below the measured number, and the stated range covers the measured number.
By their numbers in this assay, from the lowest: compounds 2, 1 and 3 (each within the scatter of the next).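

Cyano in place of formyl on this aromatic carbon gives a number 9 percentage points higher from compound 2 to compound 3 (within the scatter) in this assay, and there is a number 2 percentage points higher from compound 1 to compound 3 (within the scatter) for cyano in place of chloromethyl. Chloromethyl, formyl and cyano on this carbon therefore give numbers within the scatter of each other, so none of these swaps shows a readable effect. No measurement here offers a reason for the small differences. From the compounds shown here alone, whether an amine, a carboxylic acid or a longer chain on this carbon would move the number beyond the scatter stays open. These single-concentration readings also leave potency unknown.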